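The compounds below may be only part of what the source reports. "The series", "measured", "known", "first", "only" and "open" are said of these compounds alone.

Measured compounds:
- compound 1 `CC1CCN(C2CCN(S(=O)(=O)c3nccn3C)CC2)CC1` gives > 5000 nM
- compound 2 `Cc1cc(C)c(S(=O)(=O)N2CCC(N3CCC(C(C)C)CC3)CC2)c(C)c1` gives 0.3 nM
- compound 3 `C#CCCC(=O)CC1CCN(C2CCN(S(=O)(=O)c3c(C)cc(C)cc3C)CC2)CC1` gives 3 nM

All three were tested in a functional assay on DLD-1 cells (Homo sapiens) for antiproliferative activity, read by CellTiter-Glo, with a stated time of 72 h; on this read-out higher numbers stand for weaker inhibition and lower numbers for stronger inhibition. Compound 1 gives only a limit, > 5000 nM, so no number is known for it. Compound 2 gives 0.3 nM and compound 3 gives 3 nM; both carry a 2,4,6-trimethylphenyl group on the sulfonyl sulfur and differ from each other only on a saturated ring carbon, where the step of a 10-fold higher number from compound 2 to compound 3 (1.00 log units; beyond the scatter) is seen.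

Compound 4 `CC1CCN(C2CCN(S(=O)(=O)c3ccc(Cl)c(Cl)c3)CC2)CC1` keeps the core of compound 1 and changes the group on the sulfonyl sulfur: 3,4-dichlorophenyl in place of 1-methyl-1H-imidazol-2-yl on a sulfonyl sulfur. Among the compounds with values here, no measured pair shows this kind of exchange, so the only guide is that compound 1, with the imidazole on the sulfur, sits at the limit (the limit of > 5000 nM in this assay, at which 1 of the 3 values shown sits), while compounds 2 and 3, with a carbon-only aromatic ring on the sulfur, give small numbers. Compound 4 is therefore expected to move into the measurable range, with a step of an at least 50-fold lower number from compound 1 to compound 4 (1.69 log units; beyond the scatter) toward stronger inhibition, though its size is uncertain. Compound 4 is estimated at 100 nM, within 5 nM to 3000 nM.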

Compound 4, half-maximal inhibitory concentration: 2.9 nM
For compound 4 the middle estimate is 34-fold (1.54 log units) above the measured one; measured number outside the range, below it.
By their numbers in this assay, from the lowest: compound 2; then compounds 4 and 3 (each within the scatter of the next). At a limit, above all of these: compound 1.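

In this assay, placing 3,4-dichlorophenyl in place of 1-methyl-1H-imidazol-2-yl on a sulfonyl sulfur, with the rest of the molecule unchanged, gives an at least 1700-fold lower number from compound 1 to compound 4 (3.23 log units; beyond the scatter). This shows that the group at this position can, by itself, take the core of compound 1 from no measurable number to a very low one. Compounds 2 and 3 also give low numbers, but they differ from compound 1 in more than one place, so only this pair isolates the group on the sulfur; the true size of the step remains unknown, and compound 1 gives a limit, not a number: the limit of > 5000 nM in this assay, at which 1 of the 4 values shown sits.

On these data alone, it remains open whether the chlorine atoms are needed or whether a carbon-only ring is enough, a question that plain phenyl on the sulfonyl sulfur would help to answer. Also open, as far as these compounds go, is whether the loss seen with the imidazole extends to other rings containing nitrogen, such as pyridin-3-yl, or how a small chain such as methyl would behave at this position.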